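The compounds below may be only part of what the source reports. "The series", "measured", "known", "first", "only" and "open" are said of these compounds alone.

Measured so far:
compound 1 `Clc1ccc2c(NCCNc3nccc(Nc4ccc(Br)cc4)n3)ccnc2c1`: "not active" (no number reported)
compound 2 `COc1ccc(Nc2ccnc(NCCNc3ccnc4cc(Cl)ccc34)n2)cc1`: "not active" (no number reported)
compound 3 `Clc1ccc(Nc2ccnc(NCCCNc3ccnc4cc(Cl)ccc34)n2)cc1`: 13400 nM

Three compounds have been examined in an ADME assay on Vero cells (Chlorocebus sabaeus) for cytotoxicity, read by neutral red uptake, with a stated time of 72 h; a higher number here means a weaker inhibitor, a lower number a stronger inhibitor. Compound 1 is reported as "not active" (no number reported) and compound 2 as "not active" (no number reported), neither with a number. Among the measured compounds shown here, compound 3 is therefore the only compound with a numerical result, giving 13400 nM in this assay; with nothing else to compare against, no step between measured compounds can be drawn.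

Compound 4 `COc1ccc(Nc2ccnc(NCCCNc3ccnc4cc(Cl)ccc34)n2)cc1` is the next compound. It differs from compound 3 in one place: methoxy in place of chloro on an aromatic carbon. Since compounds 1 and 2, which carry a halogen and a methoxy group, both came out without a number, the data give no clear pointer for this exchange. The expected step from compound 3 to compound 4 is a 1.5-fold higher number from compound 3 to compound 4 (0.17 log units; within the scatter), toward a somewhat weaker effect and possibly within the scatter. Compound 4 is estimated at 20000 nM, within 8000 nM to 50000 nM.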

Compound 4, half-maximal inhibitory concentration: 13300 nM
Compound 4: the middle estimate sits 1.5-fold (0.18 log units) above what was measured, and the stated range covers the measured number.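

In this assay, putting methoxy in place of chloro on this aromatic carbon, para to a large group, gives a 1.0-fold lower number from compound 3 to compound 4 (0.00 log units; within the scatter). Among the compounds shown here, this is the first pair that allows a direct comparison, and at this position 4-chlorophenyl and 4-methoxyphenyl cannot be told apart in cytotoxicity. No available measurement explains this match. As far as these compounds go, whether an amine or a carboxylic acid on the same carbon would also leave the number in the same range remains open. So does the effect of a longer chain in the link between the two halves.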